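Bromo for amino on the aryl ring of compound 2

This account rests on a few compounds, and the source may have more. Where it says the series, first, only, none or still open, it means among the compounds named here.

Compound 1 `COc1cc2c(cc1OC)C(c1ccc([N+](=O)[O-])cc1)=NNC(=O)C2` gives only a limit in a functional assay on the whole organism with Mus musculus as the target (a higher number here means that more compound is needed for the effect, a lower number that less compound is needed), namely > 120 umol/kg. Compound 3 `COc1cc2c(cc1OC)C(c1ccccc1)=NNC(=O)C2` gives 33.9 umol/kg in this assay, and an at least 3.5-fold lower number from compound 1 to compound 3 (0.54 log units; beyond the scatter). Compound 2 `COc1cc2c(cc1OC)C(c1ccc(N)cc1)=NN=C(S)C2` gives 6.3 umol/kg in this assay, the lowest of the two numbers shown, with compound 3 the nearest at a higher number beyond the scatter. Compound 4 `COc1cc2c(cc1OC)C(c1ccc(Br)cc1)=NN=C(S)C2` differs from compound 2 in one place: bromo in place of amino on an aromatic carbon. Going by the values given here, the single measured step concerns a different substituent pair on another core, and it shows that the aryl substituent can shift the number, the unsubstituted ring giving the lower value. Among the compounds with values here, no measured step covers amino against bromo. In this assay compound 4 is expected to give 15 umol/kg, between 5 umol/kg and 50 umol/kg. The expected step of a 2.4-fold higher number from compound 2 to compound 4 (0.38 log units; beyond the scatter) is thus a modest move toward a higher number.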

Compound 4, dose for half-maximal effect: 52.1 umol/kg
For compound 4 the middle estimate is 3.5-fold (0.54 log units) below the measured one; the measured number lies above the stated range.
By their numbers in this assay, from the lowest: compound 2; then compounds 3 and 4 (each within the scatter of the next). At a limit, above all of these: compound 1.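

In this assay, the change from 4-aminophenyl to 4-bromophenyl gives an 8.3-fold higher number from compound 2 to compound 4 (0.92 log units; beyond the scatter), a direct reading that the substituent at this ring position matters on this core as well. Amino therefore gives the lower number of this pair, while the change also removes the hydrogen-bond donor and acceptor counted for amino. No measured property shown here accounts for the step.

Going by these compounds, whether the amine hydrogens are needed remains open, and dimethylamino or acetylamino at this position would test that. On these data alone, the unsubstituted phenyl ring on this same core also remains open as a reference.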